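Chloro in place of fluoro on an aromatic carbon

The source may hold more compounds than are shown below. What is called first, only, known or untested is meant among the compounds shown, and "the series" means these compounds.

In a functional assay on the whole organism for antagonist activity, with Mus musculus as the target, in the maximal electroshock model (on this read-out higher numbers stand for an effect only at larger amounts of compound and lower numbers for an effect already at smaller amounts), compound 1 `COC(=O)NC1=NC(c2ccccc2Cl)CN1` gives 50 mg/kg while compound 2 `COC(=O)NC1=NC(c2ccccc2C)CN1C` gives 68 mg/kg and compound 3 `COC(=O)NC1=NC(c2ccccc2F)CN1C` gives 74 mg/kg as its number. These three values lie within the scatter of one another, so compound 3 stands apart from neither of the others. Compound 4 `COC(=O)NC1=NC(c2ccccc2Cl)CN1C` differs from compound 3 by chloro in place of fluoro on an aromatic carbon and awaits measurement. Among the measured compounds shown here, the one measured step at this place is a 1.1-fold higher number from compound 2 to compound 3 (0.04 log units; within the scatter) for fluoro in place of methyl, and it stays within the scatter. Compound 1 also bears chloro, and its value shows no separation from the others. The step expected in this assay is a 1.2-fold lower number from compound 3 to compound 4 (0.08 log units; within the scatter) and thus nothing beyond the scatter. For compound 4 the estimated dose is 62 mg/kg with an expected range from 35 mg/kg to 110 mg/kg on this read-out.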

Compound 4, dose for half-maximal effect: 28 mg/kg
Beside the measured number, compound 4's estimate is 2.2-fold (0.35 log units) above it; the measured number lies below the stated range.
By their numbers in this assay, from the lowest: compounds 4, 1, 2 and 3 (each within the scatter of the next, the first and the last beyond it).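

In this assay chloro stands apart from the other groups at this place, with a 2.6-fold lower number from compound 3 to compound 4 (0.42 log units; beyond the scatter) for the change from fluoro and a 2.4-fold lower number from compound 2 to compound 4 (0.39 log units; beyond the scatter) for the change from methyl, a separation that the step from methyl to fluoro had not shown. Adding methyl on the amine nitrogen in the ring gives a 1.8-fold lower number from compound 1 to compound 4 (0.25 log units; within the scatter) and stays within the scatter. No supporting data bear on this result. On these data alone, whether bromo or methoxy at this aromatic carbon would match chloro remains open, as does the outcome of an ethyl on the ring nitrogen.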